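Shrinking the Ring on the Carbonyl of Compound 3

A few compounds are considered here, and "the series" means these few. Any claim that something is new, unique, unknown or untested is made for them only; others in the source may bear on it.

Three compounds share one core and differ only in the group on a carbonyl carbon. Compound 1 `CCC(=O)N1CCc2nc(C#Cc3ccccc3)sc2C1` carries an ethyl group there; in an assay on HEK293 cells for positive allosteric modulation of metabotropic glutamate receptor 5 (Homo sapiens), read by FLIPR, with a stated time of 1 h (on this read-out higher numbers stand for an effect only at larger amounts of compound and lower numbers for an effect already at smaller amounts), compound 1 reaches only the limit of the assay, > 10000 nM, and gives no number. Compound 2 `O=C(C1CCCO1)N1CCc2nc(C#Cc3ccccc3)sc2C1` carries an oxolan-2-yl group and gives 790 nM in this assay. Compound 3 `O=C(N1CCCCC1)N1CCc2nc(C#Cc3ccccc3)sc2C1` carries a piperidin-1-yl group and gives 75 nM, the lowest of the two numbers; the steps of an 11-fold lower number from compound 2 to compound 3 (1.02 log units; beyond the scatter) and an at least 130-fold lower number from compound 1 to compound 3 (2.12 log units; beyond the scatter) both point the same way. Compound 4 `O=C(N1CCCC1)N1CCc2nc(C#Cc3ccccc3)sc2C1` has not yet been measured. The change pyrrolidin-1-yl in place of piperidin-1-yl on a carbonyl carbon keeps a ring on the carbonyl but makes it one atom smaller. Within the data shown here, no measured step removes a single ring atom like this; the steps of an at least 12-fold lower number from compound 1 to compound 2 (1.10 log units; beyond the scatter) and an 11-fold lower number from compound 2 to compound 3 (1.02 log units; beyond the scatter) show that the group on the carbonyl carbon sets the number over a wide span. Since compound 4 keeps the ring joined through its nitrogen, the step of a 2.0-fold higher number from compound 3 to compound 4 (0.30 log units; within the scatter) is expected to be small, leaning slightly toward a higher number. Compound 4 is estimated at 150 nM, between 50 nM and 500 nM.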

Compound 4, half-maximal effective concentration: 9.8 nM
Compound 4: the middle estimate sits 15-fold (1.18 log units) above what was measured, outside the stated range (below it).
By their numbers in this assay, from the lowest: compound 4; then compound 3; then compound 2. At a limit, above all of these: compound 1.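

Taking one ring atom out of the group on the carbonyl carbon is no neutral swap in this assay: the step of a 7.7-fold lower number from compound 3 to compound 4 (0.88 log units; beyond the scatter) is beyond the scatter, even though both rings are joined through nitrogen and the hydrogen-bond donor and acceptor counts of the two groups are the same. The step of an 81-fold lower number from compound 2 to compound 4 (1.91 log units; beyond the scatter) widens the span already seen at this position, so pyrrolidin-1-yl now gives the lowest number among the groups shown. The step of an at least 1000-fold lower number from compound 1 to compound 4 (3.00 log units; beyond the scatter) is only a bound, since its starting point is a limit and not a number: the limit of > 10000 nM in this assay, at which 1 of the 4 values shown sits.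

From the compounds shown here alone, whether the number would fall further with the still smaller azetidin-1-yl, or hold with an open-chain dimethylamino group on the carbonyl carbon, stays open. The compounds shown also cannot tell why a single ring atom matters this much.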